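The source may hold more compounds than are shown below. What is called first, only, known or untested is meant among the compounds shown, and "the series" means these compounds.

Compound 1, `O=C(/C(=C\c1c(O)cc(O)cc1O)Sc1ccccc1Br)c1ccc(Br)cc1`, is the starting point of this account. In a functional assay on DU-145 cells (Homo sapiens) for inhibition, read by trypan blue exclusion, with a stated time of 96 h (on this read-out lower numbers stand for stronger inhibition of growth and higher numbers for weaker inhibition of growth), compound 1 gives only a limit, > 100000 nM, and no number. Compound 1 therefore stands at the limit of > 100000 nM in this assay, at which 1 of the 3 values shown sits. Among the measured compounds shown here, compound 3, `O=C(/C(=C\c1c(O)cc(O)cc1O)S(=O)(=O)c1ccccc1Br)c1ccc(Br)cc1`, gives 50000 nM in this assay, and the only step measured between close neighbours, an at least 2.0-fold lower number from compound 1 to compound 3 (0.30 log units; that floor lies within the scatter), concerns the sulfanyl-to-sulfonyl change rather than the ring that changes here. For the measured compounds named here, compound 2, `CSc1ccc(/C=C(\C(=O)c2ccc(Br)cc2)S(=O)(=O)Cc2ccc(C)cc2)cc1`, gives 10000 nM in this assay, but it differs from the other two in more than one place, so its value shows only that a compound of this shared core can reach that level. Compound 4, `CN(C)c1ccc(/C=C(/Sc2ccccc2Br)C(=O)c2ccc(Br)cc2)cc1`, differs from compound 1 by 4-(dimethylamino)phenyl in place of 2,4,6-trihydroxyphenyl on a double-bonded chain carbon bound to a double-bonded chain carbon. Going by the values given here, no measured step bears on that change, so the expectation rests on the spread of the three known values alone, with the possibility that compound 4 also returns a limit. Compound 4 is expected to give about 20000 nM in this assay, somewhere from 4000 nM to 100000 nM. That expectation amounts to an estimated at least 5.0-fold lower number from compound 1 to compound 4 (0.69 log units; beyond the scatter).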

Compound 4, concentration for 50% growth inhibition: > 100000 nM
Compound 4: no number, only a limit; the forecaster's own chance of this, stated with the estimate: 30%; middle value at least 5.0-fold (0.69 log units) from the limit.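

Compound 1 and compound 4 both return only a limit and no number, so no step can be read between them: the limit of > 100000 nM in this assay, at which 2 of the 4 values shown sit. The compounds shown leave open whether 4-(dimethylamino)phenyl in place of 2,4,6-trihydroxyphenyl changes growth inhibition in this assay at all.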